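The source may hold more compounds than are shown below. What is called first, only, known or untested is meant among the compounds shown, and "the series" means these compounds.

In a functional assay on HUVEC cells (Homo sapiens), read by scintillation counting and thymidine incorporation, with a stated time of 24 h (a lower number here means a stronger inhibitor, a higher number a weaker inhibitor), compound 2 `CCC(C)n1ncn(-c2ccc(N3CCN(c4ccc(OC[C@@H]5CO[C@@](Cn6c(C)cnc6C)(c6ccc(Cl)cc6Cl)O5)cc4)CC3)cc2)c1=O` gives 765 nM, within the scatter of compound 1 `CCC(C)n1ncn(-c2ccc(N3CCN(c4ccc(OC[C@@H]5CO[C@@](CN6CCN(C)CC6)(c6ccc(Cl)cc6Cl)O5)cc4)CC3)cc2)c1=O` at 396 nM. Compound 3 `CCC(C)n1ncn(-c2ccc(N3CCN(c4ccc(OC[C@@H]5CO[C@@](Cn6cccn6)(c6ccc(Cl)cc6Cl)O5)cc4)CC3)cc2)c1=O` carries 1H-pyrazol-1-yl in place of 2,5-dimethyl-1H-imidazol-1-yl on a saturated chain carbon bound to a saturated ring carbon. Within the data shown here, the only measured step at this place, a 1.9-fold higher number from compound 1 to compound 2 (0.29 log units; within the scatter), stays within the scatter, so no step beyond the scatter is expected in this assay. The expected step is a 1.4-fold lower number from compound 2 to compound 3 (0.14 log units; within the scatter). For compound 3 the estimated value is 550 nM, with an expected range of 220 nM to 1400 nM.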

Compound 3, half-maximal inhibitory concentration: 307 nM
The estimate for compound 3 lay 1.8-fold (0.25 log units) above the measured number; the measured number falls inside the stated range.
By their numbers in this assay, from the lowest: compounds 3, 1 and 2 (each within the scatter of the next, the first and the last beyond it).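

In this assay, this position now gives a step beyond the scatter: 1H-pyrazol-1-yl in place of 2,5-dimethyl-1H-imidazol-1-yl gives a 2.5-fold lower number from compound 2 to compound 3 (0.40 log units; beyond the scatter), a modest change that the earlier pair did not show. 1H-pyrazol-1-yl in place of 4-methylpiperazin-1-yl gives a 1.3-fold lower number from compound 1 to compound 3 (0.11 log units; within the scatter), so those two groups are not told apart here. Nothing available accounts for the step. Open, going by these compounds, is how a carboxylic acid or a simple dimethylamino group would read on this saturated chain carbon. Also open, on these data alone, is whether methyl groups on the 1H-pyrazol-1-yl ring would shift the number.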